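A few compounds are considered here, and "the series" means these few. Any claim that something is new, unique, unknown or untested is made for them only; others in the source may bear on it.

Compound 1 `CC(C)CCSc1nc(C(F)(F)F)ccc1CNC(=O)C(C)c1ccc(NS(C)(=O)=O)c(F)c1` gives 82 nM in an assay on CHO-K1 cells for antagonist activity at transient receptor potential cation channel subfamily V member 1 (Homo sapiens), read by FLIPR; on this read-out higher numbers stand for weaker inhibition and lower numbers for stronger inhibition. Compound 2 `CC(C(=O)NCc1ccc(C(F)(F)F)nc1SCCOc1ccccc1)c1ccc(NS(C)(=O)=O)c(F)c1` gives 118 nM. Compound 3 `CC1CCC(Sc2nc(C(F)(F)F)ccc2CNC(=O)C(C)c2ccc(NS(C)(=O)=O)c(F)c2)CC1` gives 180 nM.

Compound 3 stands at the highest of the three numbers: its gap to compound 2 is within the scatter, whereas a 2.2-fold higher number from compound 1 to compound 3 (0.34 log units; beyond the scatter) lies beyond it. Compound 4 `COc1ccc(CSc2nc(C(F)(F)F)ccc2CNC(=O)C(C)c2ccc(NS(C)(=O)=O)c(F)c2)cc1` differs from compound 3 by 4-methoxybenzyl in place of 4-methylcyclohexyl on a sulfur. Among the compounds with values here, two measured steps bear on this, both changes of the group on the sulfur: a 2.2-fold higher number from compound 1 to compound 3 (0.34 log units; beyond the scatter) and a 1.5-fold higher number from compound 2 to compound 3 (0.18 log units; within the scatter). Read backwards, they suggest that replacing the 4-methylcyclohexyl gives a somewhat lower number, so compound 4 is expected to move by a 1.5-fold lower number from compound 3 to compound 4 (0.18 log units; within the scatter), a step that may stay within the scatter. The estimate for compound 4 in this assay is 120 nM, with a range from 50 nM to 350 nM.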

Compound 4, half-maximal inhibitory concentration: 279 nM
Estimate against measurement, compound 4: 2.3-fold (0.37 log units) below, within the range that was stated.
By their numbers in this assay, from the lowest: compounds 1, 2, 3 and 4 (each within the scatter of the next, the first and the last beyond it).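

In this assay the 4-methoxybenzyl on the sulfur cannot be told apart from the 4-methylcyclohexyl, with a 1.6-fold higher number from compound 3 to compound 4 (0.19 log units; within the scatter) as the step, so these two ring-bearing groups read alike here. Against the chains the result is clearer: a 2.4-fold higher number from compound 2 to compound 4 (0.37 log units; beyond the scatter) from the 2-phenoxyethyl group and a 3.4-fold higher number from compound 1 to compound 4 (0.53 log units; beyond the scatter) from the isopentyl group are both modest, and they widen the span seen on this sulfur. Nothing measured here accounts for these steps. On these data alone, whether a plain benzyl, or a chain on the sulfur ending in an amine or a carboxylic acid, would read like the 4-methoxybenzyl or like the isopentyl stays open.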